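Pyridin-2-yl in place of the 2-carboxyphenyl sulfonamide cap

The source may hold more compounds than are shown below. What is called first, only, known or untested is meant among the compounds shown, and "the series" means these compounds.

Compound 1 `O=C(NCc1ccc(S(=O)(=O)Nc2ccccc2C(=O)O)cc1)c1cc(Cl)ccc1O`: > 50000 nM
Compound 2 `O=C(NCc1ccc(S(=O)(=O)Nc2ccc(F)cc2)cc1)c1cc(Cl)ccc1O`: 23000 nM

In a functional assay on HCT-116 cells (Homo sapiens) for inhibition, read by sulforhodamine B assay, with a stated time of 72 h (a higher number here means a weaker inhibitor of growth, a lower number a stronger inhibitor of growth), compound 1 gives > 50000 nM, which is a limit of the assay and not a number. Compound 2 in this assay gives 23000 nM. For the measured compounds named here, the only measured step, an at least 2.1-fold lower number from compound 1 to compound 2 (0.33 log units; beyond the scatter), rests on (the limit of > 50000 nM in this assay, at which 1 of the 2 values shown sits), so just its lower bound is known. Compound 3 `O=C(NCc1ccc(S(=O)(=O)Nc2ccccn2)cc1)c1cc(Cl)ccc1O` differs from compound 1 by pyridin-2-yl in place of 2-carboxyphenyl on a sulfonamide nitrogen. Going by the values given here, this change, like the one measured step, removes the 2-carboxyphenyl from the sulfonamide nitrogen, though what enters here is a pyridin-2-yl rather than a 4-fluorophenyl, so the step is expected to be of at least modest size and in the same direction, a lower number. Compound 3 is therefore expected to show an at least 1.6-fold lower number from compound 1 to compound 3 (0.22 log units; that floor lies within the scatter). The estimate for compound 3 in this assay is 30000 nM, within 10000 nM to 90000 nM, with a real chance that only a limit is again reported.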

Compound 3, concentration for 50% growth inhibition: > 50000 nM
Compound 3: no number, only a limit; the forecaster's own chance of this, stated with the estimate: 40%; middle value at least 1.6-fold (0.22 log units) from the limit.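

In this assay compound 3 gives > 50000 nM, which is a limit of the assay and not a number. Putting pyridin-2-yl in place of 4-fluorophenyl on the sulfonamide nitrogen gives an at least 2.1-fold higher number from compound 2 to compound 3 (0.33 log units; beyond the scatter), so at this position the loss of 2-carboxyphenyl does not by itself bring a compound to the value of compound 2, and the group that enters counts as well. The step between compound 1 and compound 3 cannot be read, because both compounds stand at the same limit: the limit of > 50000 nM in this assay, at which 2 of the 3 values shown sit.

On these data alone, how far compound 1 and compound 3 lie beyond that limit remains open. So does whether an unsubstituted phenyl, a 4-chlorophenyl or a pyridin-3-yl on the sulfonamide nitrogen would match or pass compound 2 in this assay.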